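This account rests on a few compounds, and the source may have more. Where it says the series, first, only, none or still open, it means among the compounds named here.

Compound 1 `COc1ccc(NC(=O)Nc2ccc(C(=O)NO)cc2)cc1` is the starting point of this small set. In a functional assay on MCF7 cells (Homo sapiens) for cytotoxicity, read by MTT assay, with a stated time of 72 h (on this read-out higher numbers stand for weaker inhibition and lower numbers for stronger inhibition), compound 1 gives > 50000 nM, which is a limit of the assay rather than a number. Compound 2 `O=C(Nc1ccc(C(=O)NO)cc1)Nc1ccc([N+](=O)[O-])cc1` differs from compound 1 by nitro in place of methoxy on an aromatic carbon. In this assay compound 2 gives > 50000 nM, again a limit and not a measured number. The step that the two limits leave unreadable from compound 1 to compound 2 therefore cannot be sized. Compound 3 `COc1ccc(NC(=O)Nc2ccc(CCC(=O)NO)cc2)cc1` has a different core from compound 1, the difference being (2-(hydroxycarbamoyl)ethyl in place of hydroxycarbamoyl on an aromatic carbon). In this assay compound 3 gives > 50000 nM, which is also only a limit. The step that the two limits leave unreadable from compound 1 to compound 3 is equally unreadable. What the three measured compounds share is the limit of > 50000 nM in this assay, at which 3 of the 3 values shown sit.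

Compound 4 `O=C(CCc1ccc(NC(=O)Nc2ccc([N+](=O)[O-])cc2)cc1)NO` has not yet been measured. It differs from compound 3 by nitro in place of methoxy on an aromatic carbon, and this is the same change, at the same place, as that from compound 1 to compound 2. The earlier step that the two limits leave unreadable from compound 1 to compound 2 gave nothing readable because all the values involved sit at the limit of > 50000 nM in this assay, at which 3 of the 3 values shown sit. The step from compound 3 to compound 4 is expected to be about a step that the limit leaves unreadable from compound 3 to compound 4, an expectation that rests on compound 3 sitting at the limit of > 50000 nM in this assay, at which 3 of the 3 values shown sit. Compound 4 is therefore expected to give roughly 60000 nM in this assay, with a likely range from 20000 nM to 200000 nM, most probably reported once more only as a limit.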

Compound 4, half-maximal inhibitory concentration: > 50000 nM
Compound 4: no number, only a limit; the forecaster's own chance of this, stated with the estimate: 85%; the middle value does not contradict the limit.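

In this assay compound 4 gives > 50000 nM as a limit and not a number. Neither the step from compound 3 to compound 4 nor the step from compound 2 to compound 4 can be read, because no compound shown has a measured number: the limit of > 50000 nM in this assay, at which 4 of the 4 values shown sit. The compounds shown leave open whether nitro in place of methoxy, or 2-(hydroxycarbamoyl)ethyl in place of hydroxycarbamoyl, changes the result in this assay at all.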